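A Bromo-for-Fluoro Swap in Three Related Growth Inhibitors

The compounds below may be only part of what the source reports. "The series", "measured", "known", "first", "only" and "open" are said of these compounds alone.

Compound 1 `COc1cc2ncnc(Nc3ccccc3F)c2c(OC)c1OC`, compound 2 `COc1cc2ncnc(Nc3cc(C(F)(F)F)ccc3F)c2c(OC)c1OC` and compound 3 `COc1cc2ncnc(Nc3ccccc3[N+](=O)[O-])c2c(OC)c1OC` share one core and differ only in the groups carried on one ring. In a functional assay on PC-3 cells (Homo sapiens) for inhibition, read by MTT assay, with a stated time of 72 h, tested at 10 uM (a higher number here means more inhibition of growth at the concentration tested, a lower number less inhibition of growth), compound 1 gives 24%, compound 2 gives 29.2% and compound 3 gives 25.5%. Compound 2 holds the highest of the three numbers, yet both gaps to it lie within the scatter, so the three cannot be told apart. Compound 4 `COc1cc2ncnc(Nc3cc(C(F)(F)F)ccc3Br)c2c(OC)c1OC` differs from compound 2 by bromo in place of fluoro on an aromatic carbon. Within the data shown here, no measured step makes this exact change; the nearest is a number 1.5 percentage points higher from compound 1 to compound 3 (within the scatter), a swap of one group for another that stayed within the scatter, as did a number 5.2 percentage points higher from compound 1 to compound 2 (within the scatter). A step of a number 0.8 percentage points higher from compound 2 to compound 4 (within the scatter) is therefore expected, nothing beyond the scatter. Compound 4 is estimated at 30%, between 18% and 42%.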

Compound 4, percent growth inhibition at one concentration: 25.3%
Compound 4: middle estimate off by 4.7 percentage points, on the high side, and the stated range covers the measured number.
By their numbers in this assay, from the lowest: compounds 1, 4, 3 and 2 (each within the scatter of the next).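

Putting bromo in place of fluoro on this aromatic carbon, para to a trifluoromethyl group, gives a number 3.9 percentage points lower from compound 2 to compound 4 (within the scatter) in this assay at the one concentration tested. Compounds 2 and 4 therefore cannot be told apart, so at this position the two halogens give no readable difference, with the trifluoromethyl group held in place. No measurement available here bears on what lies behind this result. On these data alone, whether an amine, a carboxylic acid or a longer chain on this carbon would move the number beyond the scatter remains open.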